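The source may hold more compounds than are shown below. What is called first, only, known or untested is meant among the compounds shown, and "the series" means these compounds.

Working notes on the series. Compound 1 `CO[C@@H]1CC=C2NN(c3cc(Cl)cc(Cl)c3)C(=O)C[C@]2(C)O1` and compound 2 `CO[C@@H]1CC=C2NN(c3cc(Cl)cc(Cl)c3)C(=O)C[C@]2(c2ccncc2)O1` share one core; compound 3 `COc1cc(OC)cc(N2NC3=CC[C@@H](OC)O[C@@]3(C)CC2=O)c1` and compound 4 `COc1cc(OC)cc(N2NC3=CC[C@@H](OC)O[C@@]3(c3ccncc3)CC2=O)c1` share another. The difference between the two cores is not broken down here.

In a functional assay on SK-N-SH cells (Homo sapiens) for inhibition, read by sulforhodamine B assay, with a stated time of 48 h (a lower number here means a stronger inhibitor, a higher number a weaker inhibitor), compound 1 gives 20200 nM. Compound 2 carries pyridin-4-yl in place of methyl on a saturated ring carbon and gives 8300 nM, so the step runs a 2.4-fold lower number from compound 1 to compound 2 (0.39 log units; beyond the scatter). Compound 3 gives 23700 nM, which lies within the scatter of the number for compound 1; the two cores are therefore not separated by these data.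

Compound 4 is not yet measured. It carries pyridin-4-yl in place of methyl on a saturated ring carbon, the same kind of change as that seen from compound 1 to compound 2, though the surroundings are described differently: in compound 2 the carbon sits in a six-membered non-aromatic ring with 1 oxygen, next to the ring oxygen, next to the ring atom that bears a fused ring, two ring bonds from the ring atom that bears a methoxy group; in compound 4 it sits in a six-membered non-aromatic ring with 2 nitrogen, two ring bonds from the ring nitrogen, three ring bonds from the ring nitrogen, three ring bonds from the ring atom that bears a large group.

Among the measured compounds shown here, the step of a 2.4-fold lower number from compound 3 to compound 4 (0.37 log units; beyond the scatter) is expected to be of similar size because a 2.4-fold lower number from compound 1 to compound 2 (0.39 log units; beyond the scatter) is the single precedent for this change. Compound 4 is accordingly expected near 10000 nM, within an expected range of 5000 nM to 21000 nM.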

Compound 4, half-maximal inhibitory concentration: 6400 nM
Estimate against measurement, compound 4: 1.6-fold (0.19 log units) above; measured number inside the range.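

In this assay the exchange of methyl for pyridin-4-yl on a saturated ring carbon gives a 3.7-fold lower number from compound 3 to compound 4 (0.57 log units; beyond the scatter), so the number falls on the core of compound 3 as it did on the core of compound 1. The two steps run in the same direction and their sizes are not separated, so on these two cores the change carries over: the same change on two cores in this assay, a 2.4-fold lower number (0.39 log units; beyond the scatter) from compound 1 to compound 2 and a 3.7-fold lower number (0.57 log units; beyond the scatter) from compound 3 to compound 4, 1.5-fold (0.18 log units) apart, within the scatter of two such steps. This does not show why the number falls, and two cores set no rule for any further core; the two steps also say nothing about how the cores themselves compare.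

The compounds shown leave open whether the lower number is particular to pyridin-4-yl, or would also follow from a phenyl ring, a pyridin-3-yl group, an amine, a carboxylic acid or a longer chain on that saturated ring carbon. They also leave open whether the step would hold on a core whose aromatic ring carries neither the chloro nor the methoxy groups, and whether it would be seen at all outside this assay.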